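A sulfonamide chain in place of the hydroxypiperidine amide

The compounds below may be only part of what the source reports. "The series", "measured", "known", "first", "only" and "open" are said of these compounds alone.

Measured in an assay on HEK293 cells for displacement of a labelled ligand from NPC1-like intracellular cholesterol transporter 1 (Homo sapiens); on this read-out lower numbers stand for stronger inhibition and higher numbers for weaker inhibition:
compound 1 `CC(C)(C)c1ccc(C(=O)N2CCC3(CC2)C(=O)N(CC(=O)N2CCCC(O)C2)CN3c2ccccc2)cc1` — 12200 nM
compound 2 `CC(C)(C)OC(=O)NCC1CCCN(C(=O)CN2CN(c3ccccc3)C3(CCN(C(=O)c4ccc(C(C)(C)C)cc4)CC3)C2=O)C1` — 9500 nM

Compound 1 carries the highest of the two numbers, but that standing means little, since the step of a 1.3-fold lower number from compound 1 to compound 2 (0.11 log units; within the scatter) lies within the scatter. Compound 3 `CC(C)(C)c1ccc(C(=O)N2CCC3(CC2)C(=O)N(CC(=O)NCCCCNS(C)(=O)=O)CN3c2ccccc2)cc1` differs from compound 1 as follows: (4-(methanesulfonamido)butyl)amino in place of 3-hydroxypiperidin-1-yl on a carbonyl carbon. Within the data shown here, the single measured step touched only the substituent on that ring and did not move the number beyond the scatter; an exchange of the whole ring for an open chain has no measured counterpart here, so nothing argues for a large change in either direction. Compound 3 is therefore estimated at 10000 nM, within 3000 nM to 35000 nM. For compound 3 the expected step is a 1.2-fold lower number from compound 1 to compound 3 (0.09 log units; within the scatter), not beyond the scatter.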

Compound 3, half-maximal inhibitory concentration: 4500 nM
Beside the measured number, compound 3's estimate is 2.2-fold (0.35 log units) above it; the measured number falls inside the stated range.
By their numbers in this assay, from the lowest: compound 3; then compounds 2 and 1 (each within the scatter of the next).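

In this assay, (4-(methanesulfonamido)butyl)amino in place of 3-hydroxypiperidin-1-yl on the carbonyl carbon gives a 2.7-fold lower number from compound 1 to compound 3 (0.43 log units; beyond the scatter). Unlike the change on the ring substituent, this exchange of the whole ring for an open chain moves the number beyond the scatter, though only modestly. Nothing available explains this shift.

From the compounds shown here alone, what stays open is whether the step belongs to the methanesulfonamido end or to the open chain itself. Going by these compounds, it is also open how a plain butylamino group, a longer chain or a terminal carboxylic acid would compare.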